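This account rests on a few compounds, and the source may have more. Where it says the series, first, only, none or still open, it means among the compounds named here.

Four compounds share one core, an amide joined to an aromatic ring that carries an unsaturated ester. In an assay on isolated protein with Bile acid receptor (Homo sapiens) as the target (a lower number here means that less compound is needed, a higher number that more compound is needed for the effect), compound 1 `COC(=O)/C=C/c1cccc(N(Cc2ccc(/C=C/c3c(C)cc(C)cc3C)cc2)C(=O)C(C)C)c1` gives 149 nM. Compound 2 `COC(=O)/C=C/c1cccc(N(Cc2ccc(/C=C/c3scnc3C)cc2)C(=O)C2CCCCC2)c1` gives 227 nM in this assay. Compound 3 `COC(=O)/C=C/c1cccc(NC(=O)C2CCCCC2)c1` carries only a hydrogen on its amide-type nitrogen. For compound 3, this assay reports only a limit, > 1000 nM. Compound 3 thus sits at the limit of > 1000 nM in this assay, at which 1 of the 3 values shown sits, so its true value is not known, only that it lies beyond what the measurement could resolve.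

Compound 4 `COC(=O)/C=C/c1cccc(N(Cc2cccc(OC)c2)C(=O)C2CCCCC2)c1` is reached from compound 3 by one change: 3-methoxybenzyl in place of hydrogen on an amide-type nitrogen. Compounds 1 and 2 both carry a substituted benzyl group on that same nitrogen and both give measurable values, while compound 3 with bare hydrogen does not. Compound 4 carries a benzyl group of a different kind, without the extension present in compounds 1 and 2. A step away from the limit into the measurable range is therefore expected, though not necessarily as far as compounds 1 and 2 reach. The expected step from compound 3 to compound 4 is an at least 1.6-fold lower number from compound 3 to compound 4 (0.22 log units; that floor lies within the scatter). Compound 4 is expected to give about 600 nM, within a range from 200 nM to 2000 nM.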

Compound 4, half-maximal effective concentration: > 1000 nM
Compound 4 gave a limit, no number; the forecaster's own chance of this, stated with the estimate: 35%; middle value at least 1.6-fold (0.22 log units) from the limit.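

In this assay compound 4 gives only a limit, > 1000 nM. Compound 3 stands at a limit too, so no step between compound 3 and compound 4 can be read: the limit of > 1000 nM in this assay, at which 2 of the 4 values shown sit.

The compounds shown leave open whether 3-methoxybenzyl in place of hydrogen on the amide-type nitrogen changes the value at all.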